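The source may hold more compounds than are shown below. What is called first, only, known or untested is meant among the compounds shown, and "the series" means these compounds.

Measured in a functional assay on MDA-MB-453 cells (Homo sapiens) for antiproliferative activity, read by MTT assay, with a stated time of 72 h; a higher number here means a weaker inhibitor, a lower number a stronger inhibitor:
- compound 1 `CCOC(=O)c1c[nH]nc1N/C=C1\C(=O)NN=C1c1ccccc1`: 74600 nM
- compound 2 `O=C1NN=C(c2ccccc2)/C1=C/Nc1cc(-c2ccco2)[nH]n1`: 20900 nM
- compound 3 `O=C1NN=C(c2ccccc2)/C1=C/Nc1cc[nH]n1`: 74900 nM

Compound 3 stands level with compound 1 at the weak end of this small set, and compound 2 is the only one clearly apart. Compound 4 `O=C1NN=C(c2ccccc2)/C1=C/N[C@@H](CO)C(=O)O` carries 1-carboxy-2-hydroxyethyl in place of 1H-pyrazol-3-yl on an amine nitrogen. The measured steps bear on this only indirectly, as each changes a group on an aromatic carbon: a 1.0-fold higher number from compound 1 to compound 3 (0.00 log units; within the scatter) and the modest 3.6-fold higher number from compound 2 to compound 3 (0.55 log units; beyond the scatter). Among the measured compounds shown here, no measured compound lacks the ring that leaves here, so only a small shift in this assay, toward a higher number, is expected. The expected change is a 1.2-fold higher number from compound 3 to compound 4 (0.08 log units; within the scatter). The estimate for compound 4 is 90000 nM, with an expected range of 35000 nM to 250000 nM.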

Compound 4, half-maximal inhibitory concentration: 23700 nM
Compound 4: the middle estimate sits 3.8-fold (0.58 log units) above what was measured; the measured number lies below the stated range.
By their numbers in this assay, from the lowest: compounds 2 and 4 (each within the scatter of the next); then compounds 1 and 3 (each within the scatter of the next).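

In this assay the swap of 1H-pyrazol-3-yl for 1-carboxy-2-hydroxyethyl on the amine nitrogen gives a 3.2-fold lower number from compound 3 to compound 4 (0.50 log units; beyond the scatter) and so shows that this position tolerates loss of the aromatic ring. The earlier steps shown here changed only groups on an aromatic carbon, so they could not show this. No evidence here accounts for the step.

The compounds shown leave open whether the carboxylic acid or the hydroxyl group of the new chain matters more. They also leave open how a methyl ester or an amide in place of that acid, or the opposite stereocentre, would read.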